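Methoxyphenyl Replaces Difluorophenyl in a Cytotoxicity Series

This account rests on a few compounds, and the source may have more. Where it says the series, first, only, none or still open, it means among the compounds named here.

For the measured compounds named here, the three compounds measured so far share one core and differ only in the group on the saturated chain carbon bound to a sulfur. Compound 1 `COc1cc(-c2nnc(SCc3ccc([N+](=O)[O-])cc3)o2)ccc1O` carries a 4-nitrobenzyl-type group there, compound 2 `COc1cc(-c2nnc(SCc3ccccc3[N+](=O)[O-])o2)ccc1O` a 2-nitro analogue, and compound 3 `COc1cc(-c2nnc(SCc3c(F)cccc3F)o2)ccc1O` a 2,6-difluorophenyl. In an ADME assay on cells (Mus musculus, strain BALB/c) for cytotoxicity, read by MTT assay, with a stated time of 24 h (a higher number here means that more compound is tolerated, a lower number that less compound is tolerated), compound 1 gives 688000 nM, compound 2 gives 331000 nM, and compound 3 gives 575000 nM. Compound 3 thus sits in the same band as the other two: its number is closest to that of compound 1 and furthest from that of compound 2, yet both gaps fall within the usual scatter of this kind of measurement, so no ranking among the three can be read from them.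

Compound 4 `COc1cccc(CSc2nnc(-c3ccc(O)c(OC)c3)o2)c1` is the next member. It differs from compound 3 as follows: 3-methoxyphenyl in place of 2,6-difluorophenyl on a saturated chain carbon bound to a sulfur. Going by the values given here, no pair of measured compounds differing in one place exists, so no measured step sets a scale for this change. Given that all three measured numbers lie within scatter of one another, compound 4 is expected to show no step in this assay beyond the scatter, a 1.0-fold lower number from compound 3 to compound 4 (0.02 log units; within the scatter). The estimate for compound 4 is 550000 nM, with a range from 280000 nM to 1000000 nM.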

Compound 4, half-maximal cytotoxic concentration: 389000 nM
Compound 4: the middle estimate sits 1.4-fold (0.15 log units) above what was measured, within the range that was stated.
By their numbers in this assay, from the lowest: compounds 2, 4, 3 and 1 (each within the scatter of the next, the first and the last beyond it).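

Read in this assay, the exchange of 3-methoxyphenyl for 2,6-difluorophenyl on a saturated chain carbon bound to a sulfur provides the first step in this series between compounds that differ in one place: a 1.5-fold lower number from compound 3 to compound 4 (0.17 log units; within the scatter). It shows that this particular exchange, in which a ring carrying fluorine gives way to a ring carrying a methoxy group and the count of hydrogen-bond acceptors on the group goes from 0 to 1, does not produce a step beyond the usual scatter of the measurement. No measured information on the cause of this result is available, and the step alone cannot supply one.

The compounds shown leave open whether any group at this place can move the number beyond the scatter, since every group here contains a six-membered aromatic ring of carbon only, and an amine, a carboxylic acid or a longer chain would test the position in a different way. They also leave open whether 4-methoxyphenyl or 2-methoxyphenyl would give a step of the same size as 3-methoxyphenyl.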